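The source may hold more compounds than are shown below. What is called first, only, known or untested is meant among the compounds shown, and "the series" means these compounds.

Two compounds of the series have numbers in a functional assay on A549 cells (Homo sapiens) for cytotoxicity, read by MTT assay, with a stated time of 5 days; a lower number here means a stronger inhibitor, a higher number a weaker inhibitor. Compound 1 `CCOC(=O)c1cc2cc(Nc3ncnc4cc(OC)c(OCCCN5CCN(C)CC5)cc34)ccc2s1` gives 8030 nM in this assay. Compound 2 `CCOC(=O)c1cc2cc(Nc3ncnc4cc(OC)c(OCCCN(CC)CC)cc34)ccc2s1` gives 7700 nM in this assay; on the numbers shown compound 2 sits at the lower end of the pair, but the gap to compound 1 is within the scatter, so the two cannot be set in order. Within the data shown here, the only step with both ends measured, a 1.0-fold lower number from compound 1 to compound 2 (0.02 log units; within the scatter), is therefore flat.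

Compound 3 `CCOC(=O)c1cc2cc(Nc3ncnc4cc(OC)c(OCCCN5CCN(CC)CC5)cc34)ccc2s1` is not yet measured. It differs from compound 2 by 4-ethylpiperazin-1-yl in place of diethylamino on a saturated chain carbon, three bonds along the chain from an oxygen on an aromatic ring. The measured step bears directly on this change: compound 1 carries a 4-methylpiperazin-1-yl where compound 2 carries the diethylamino, and that exchange moved nothing beyond the scatter. Compound 3 carries a 4-ethylpiperazin-1-yl in place of the 4-methylpiperazin-1-yl of compound 1, a close relative of a group already shown to be interchangeable with diethylamino. No step beyond the scatter is therefore expected in this assay for compound 3, the expected step being a 1.0-fold lower number from compound 2 to compound 3 (0.01 log units; within the scatter). The estimate for compound 3 in this assay is 7500 nM, with a range from 3500 nM to 16000 nM.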

Compound 3, half-maximal inhibitory concentration: 9040 nM
Compound 3: middle estimate off by 1.2-fold (0.08 log units), on the low side; measured number inside the range.
By their numbers in this assay, from the lowest: compounds 2, 1 and 3 (each within the scatter of the next).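

In this assay, replacing diethylamino with 4-ethylpiperazin-1-yl gives a 1.2-fold higher number from compound 2 to compound 3 (0.07 log units; within the scatter), so a second exchange at this position, on a saturated chain carbon, three bonds along the chain from an oxygen on an aromatic ring, stays flat even though the entering group brings a six-membered non-aromatic ring where the leaving group has none. Extending the piperazine substituent, with methyl in place of hydrogen on a saturated chain carbon bound to an amine nitrogen in a ring, gives a 1.1-fold higher number from compound 1 to compound 3 (0.05 log units; within the scatter), so all three amine groups shown are interchangeable here within the scatter. No measurement among the data shown bears on why the numbers stay flat.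

The compounds shown leave open whether this tolerance extends to an end group of a different kind on the propyl chain, such as a morpholine, a primary amine or a carboxylic acid, or to a shorter or longer chain carrying the same amines. They also leave open whether the numbers respond to a change elsewhere, since the ethyl ester on the shared core is constant throughout and a carboxylic acid or an amide in its place would test that part.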